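The source may hold more compounds than are shown below. What is called first, only, known or untested is meant among the compounds shown, and "the series" means these compounds.

Measured so far in an assay on isolated protein for binding affinity to growth hormone secretagogue receptor type 1 (Homo sapiens); a lower number here means a stronger inhibitor, a higher number a weaker inhibitor:
compound 1 `CCN(CC)c1ccc(NC(=O)c2c(-c3c(Cl)cccc3Cl)noc2C)c(C(F)(F)F)c1`: 4100 nM
compound 2 `CCC(CC)c1ccc(NC(=O)c2c(-c3c(Cl)cccc3Cl)noc2C)cc1`: > 10000 nM

Compound 2 sits at the limit of > 10000 nM in this assay, at which 1 of the 2 values shown sits; its value is a limit of the assay and not a number. Going by the values given here, compound 1 in this assay gives 4100 nM, a measured number, but compound 1 and compound 2 differ in more than one place, so the two values show only that one compound is measurable and the other is not.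

Compound 3 `CCNc1ccc(NC(=O)c2c(-c3c(Cl)cccc3Cl)noc2C)cc1` is not yet measured. It differs from compound 2 by ethylamino in place of pentan-3-yl on an aromatic carbon. Among the compounds with values here, since compound 2 gives only a limit, no step between measured compounds carries over to this change. Within the data shown here, compound 1, which carries a diethylamino group rather than a carbon chain on the same ring, gives 4100 nM, and that is the only measured value for a nitrogen substituent at this position.

Compound 3 is expected to come out near the weak end of this assay, estimated at 6000 nM, range 1500 nM to 20000 nM. The expected step of an at least 1.6-fold lower number from compound 2 to compound 3 (0.22 log units; that floor lies within the scatter) cannot be sized from a limit; a reading that is again only a limit is a real possibility.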

Compound 3, half-maximal inhibitory concentration: > 10000 nM
Compound 3: no number, only a limit (the forecaster's own chance of this, stated with the estimate: 40%); middle value at least 1.6-fold (0.22 log units) away from the limit.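

In this assay compound 3 gives > 10000 nM, a limit of the assay and not a number. Compound 2 also stands at a limit, so no step from compound 2 to compound 3 can be read: the limit of > 10000 nM in this assay, at which 2 of the 3 values shown sit.

The compounds shown leave open whether ethylamino in place of pentan-3-yl on an aromatic carbon changes the read-out at all, and by how much.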